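Isopropyl in place of methyl at the ring nitrogen

The source may hold more compounds than are shown below. What is called first, only, known or untested is meant among the compounds shown, and "the series" means these compounds.

In a functional assay on CHO cells for antagonist activity at adenosine receptor A2b (Homo sapiens), read by 33P incorporation, with a stated time of 20 min, in the presence of a further agent that is not named here (on this read-out higher numbers stand for weaker inhibition and lower numbers for stronger inhibition), compound 2 `Cn1cc2c(Cl)nc(N)nc2n1` gives only a limit, > 20000 nM. Compound 1 `CC(C)(C)Cn1cc2c(Cl)nc(N)nc2n1` likewise gives only a limit in this assay, > 10000 nM. Among the measured compounds shown here, the one measured step, a step that the two limits leave unreadable from compound 1 to compound 2, is thus unreadable, as the two limits the limit of > 10000 nM in this assay, at which 1 of the 2 values shown sits, and the limit of > 20000 nM in this assay, at which 1 of the 2 values shown sits, show. Compound 3 `CC(C)n1cc2c(Cl)nc(N)nc2n1` differs from compound 2 by isopropyl in place of methyl on an aromatic nitrogen. No readable step bears on this change, so the expected step of an at least 1.3-fold lower number from compound 2 to compound 3 (0.12 log units; that floor lies within the scatter) is none beyond the scatter. Compound 3 is therefore estimated at 15000 nM in this assay, within 4000 nM to 60000 nM.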

Compound 3, inhibition constant: > 10000 nM
Compound 3 ended at the assay's limit (the forecaster's own chance of this, stated with the estimate: 80%); the middle value lies beyond the limit too.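

Among the compounds shown here, compound 3, like compound 1 and compound 2, gives only a limit in this assay, so no step among the three can be read. The compounds shown leave open whether methyl, isopropyl or neopentyl on the aromatic nitrogen differ at all.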